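Acetyl on the sulfonamide nitrogen of a dihydroxy pyrazole analogue

A few compounds are considered here, and "the series" means these few. Any claim that something is new, unique, unknown or untested is made for them only; others in the source may bear on it.

Of the compounds shown here, three have been measured in a functional assay on cells (Cancer cell lines, Homo sapiens) for cytotoxicity, read by sulforhodamine B assay, with a stated time of 48 h; on this read-out lower numbers stand for stronger inhibition of growth and higher numbers for weaker inhibition of growth. Compound 1 `COc1ccc(OC)c(-c2cc(-c3ccccc3)nn2-c2ccc(S(=O)(=O)NC(C)=O)cc2)c1` gives 28800 nM. Compound 2 `Oc1ccc(O)c(-c2cc(-c3ccccc3)nn2-c2ccccc2)c1` gives 100000 nM, and compound 3 `NS(=O)(=O)c1ccc(-n2nc(-c3ccccc3)cc2-c2cc(O)ccc2O)cc1` gives 100000 nM. Compound 3 therefore stands level with compound 2, the two together at the highest numbers of the set, while compound 1 sits at a lower number, a gap that lies beyond the usual scatter.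

Compound 4 `CC(=O)NS(=O)(=O)c1ccc(-n2nc(-c3ccccc3)cc2-c2cc(O)ccc2O)cc1` differs from compound 3 in one place: acetyl in place of hydrogen on a sulfonamide nitrogen. Among the measured compounds shown here, no measured pair shows this exact change. For the measured compounds named here, the one measured step, no change at the digits printed from compound 2 to compound 3 (within the scatter), added the sulfamoyl group itself and left the number where it was. Compound 1 carries the same acetylsulfamoyl group as compound 4 but differs from it elsewhere, so its value can only hint that the acetylated sulfonamide is compatible with a somewhat lower number.

Compound 4 is therefore expected to give 80000 nM, with a range from 30000 nM to 150000 nM, and the expected step of a 1.3-fold lower number from compound 3 to compound 4 (0.10 log units; within the scatter) is small, leaning weakly toward a lower number because compound 1 gives 28800 nM.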

Compound 4, concentration for total growth inhibition: 100000 nM
Estimate against measurement, compound 4: 1.3-fold (0.10 log units) below; the range from low to high includes it.
By their numbers in this assay, from the lowest: compound 1; then compounds 2, 3 and 4 (each within the scatter of the next).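

In this assay, acetyl on the sulfonamide nitrogen gives no change at the digits printed from compound 3 to compound 4 (within the scatter), and the whole acetylsulfamoyl group in place of hydrogen on an aromatic carbon gives no change at the digits printed from compound 2 to compound 4 (within the scatter), so neither change moves the number on the 2,5-dihydroxyphenyl compounds. With the acetylsulfamoyl group kept in place, 2,5-dihydroxyphenyl in place of 2,5-dimethoxyphenyl gives a 3.5-fold higher number from compound 1 to compound 4 (0.54 log units; beyond the scatter), a modest step and the only one here beyond the scatter, so among these compounds the lower number of compound 1 goes with its 2,5-dimethoxyphenyl group and not with the acetylsulfamoyl group alone. Nothing in the data shown explains why these changes do or do not alter the number.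

It stays open whether acetyl on the sulfonamide nitrogen would count for anything with 2,5-dimethoxyphenyl in place: compound 1 is the only compound shown with that group, and it has no partner with a plain sulfamoyl group or a hydrogen at that spot. As far as these compounds go, it is also open whether a longer chain on the sulfonamide nitrogen, or a carboxylic acid in place of the whole sulfamoyl group, would shift the number away from that of compound 3.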